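Working notes: from compound 1 to compound 3

The compounds below may be only part of what the source reports. "The series", "measured", "known", "first", "only" and "open" are said of these compounds alone.

Measured so far in a functional assay on SK-N-AS cells (Homo sapiens) for antiproliferative activity, with a stated time of 72 h; on this read-out higher numbers stand for weaker inhibition and lower numbers for stronger inhibition:
- compound 1 `Cc1cc(C)cc(C(=O)N(CCC(=O)NCc2ccccc2)Cc2ccc(C(=O)NO)cc2)c1`: 1860 nM
- compound 2 `Cc1ccc(CNC(=O)CCN(Cc2ccc(C(=O)NO)cc2)C(=O)c2ccc(N(C)C)cc2)cc1`: 340 nM

Of these two values, compound 1 has the higher number and so the weaker inhibition in this assay. The gap to compound 2 lies beyond the usual scatter. However, the two compounds differ in more than one place, so that gap cannot be assigned to any single group.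

The next compound, still unmeasured, is compound 3 `Cc1ccc(C(=O)N(CCC(=O)NCc2ccccc2)Cc2ccc(C(=O)NO)cc2)cc1`. Relative to compound 1 it carries 4-methylphenyl in place of 3,5-dimethylphenyl on a carbonyl carbon, with 4-methylphenyl in place of 3,5-dimethylphenyl on a carbonyl carbon. Among the compounds with values here, no measured pair in this small set isolates that change, so the anchor is compound 1 at 1860 nM. The change is small, and no step beyond the scatter is expected, with any movement more likely toward a lower number. The estimated change is a 1.4-fold lower number from compound 1 to compound 3 (0.16 log units; within the scatter). For compound 3 the expected value is 1300 nM, with an estimated range from 500 nM to 3200 nM.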

Compound 3, half-maximal inhibitory concentration: 910 nM
The estimate for compound 3 lay 1.4-fold (0.15 log units) above the measured number; measured number inside the range.
By their numbers in this assay, from the lowest: compound 2; then compound 3; then compound 1.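

This gives the series its first comparison that differs in one place: on the carbonyl carbon whose other neighbour is the amide-type nitrogen, 4-methylphenyl in place of 3,5-dimethylphenyl in this assay gives a 2.0-fold lower number from compound 1 to compound 3 (0.31 log units; beyond the scatter) as a modest step, so the read-out responds to the substitution of this aromatic ring even when the change is small. The group goes from 8 heavy atoms to 7, with one six-membered aromatic ring of carbon only and no hydrogen-bond donors or acceptors on either side, yet the number and the placing of the methyl groups change together, so this single step cannot separate the two. No supporting measurement bears on why the number moves.

Still open, on these data alone, is whether the trend continues with an unsubstituted phenyl, or with a ring carrying a carboxylic acid or a primary amine, on the same carbonyl carbon. Compound 2 differs from both compound 1 and compound 3 in more than one place, so its value cannot yet be tied to any one group, and a single pair offers no general rule for this position.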